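The source may hold more compounds than are shown below. What is called first, only, known or untested is meant among the compounds shown, and "the series" means these compounds.

In a functional assay on A549 cells (Homo sapiens) for cytotoxicity, read by sulforhodamine B assay, with a stated time of 72 h (a higher number here means a weaker inhibitor, a lower number a stronger inhibitor), compound 1 `Nc1sc(-c2ccccc2)c(-c2ccc(Cl)cc2)c1C(=O)NC1CC1` gives 4300 nM. Compound 2 `Nc1sc(-c2ccccc2)c(-c2ccc(Cl)cc2)c1C(=O)N1CCCC1` carries pyrrolidin-1-yl in place of cyclopropylamino on the carbonyl carbon and gives 5800 nM in this assay; the step of a 1.3-fold higher number from compound 1 to compound 2 (0.13 log units; within the scatter) stays within the usual scatter of such measurements. Among the measured compounds shown here, of the two numbers so far, compound 2 holds the top one, yet the gap to compound 1 is too small to tell the two apart.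

Compound 3 `Nc1sc(-c2ccccc2)c(-c2ccc(Cl)cc2)c1C(=O)NCc1ccccc1` has not been measured yet. Its structure differs from compound 2 in one place: benzylamino in place of pyrrolidin-1-yl on a carbonyl carbon. For the measured compounds named here, the only measured step that touches this position is the exchange at the carbonyl carbon between compound 1 and compound 2, and a 1.3-fold higher number from compound 1 to compound 2 (0.13 log units; within the scatter) did not move the number beyond the scatter. Going by the values given here, with a single such comparison, and no benzylamino compound among the measured ones, a change of similar size is the most that can be expected, in either direction or none at all. Compound 3 is therefore expected to give about 5000 nM in this assay, most likely between 2000 nM and 15000 nM. This estimate means a step of a 1.2-fold lower number from compound 2 to compound 3 (0.06 log units; within the scatter) that is expected to remain within the scatter.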

Compound 3, half-maximal inhibitory concentration: 8510 nM
Estimate against measurement, compound 3: 1.7-fold (0.23 log units) below, and the stated range covers the measured number.
By their numbers in this assay, from the lowest: compounds 1, 2 and 3 (each within the scatter of the next).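

Benzylamino brings a six-membered aromatic ring of carbon only and a hydrogen-bond donor that pyrrolidin-1-yl lacks, yet the change gives a 1.5-fold higher number from compound 2 to compound 3 (0.17 log units; within the scatter) in this assay. Replacing the cyclopropyl on the amide-type nitrogen with benzyl gives a 2.0-fold higher number from compound 1 to compound 3 (0.30 log units; within the scatter), so even this larger aromatic group cannot be told apart from either of the other two groups, and this position has so far shown no measurable preference among the three. The data offer no independent measurement that could explain this flat result.

From the compounds shown here alone, all three groups on the carbonyl carbon are joined through nitrogen and contain only carbon beyond it, so it remains open whether a morpholine ring, a longer chain ending in an amine, or a carboxylic acid would move the number beyond the scatter. The rest of the shared core is the same in all three compounds, so these results also cannot show how the number would respond to a change anywhere else on the molecule.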